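A few compounds are considered here, and "the series" means these few. Any claim that something is new, unique, unknown or untested is made for them only; others in the source may bear on it.

Measured compounds:
compound 1, `Nc1ccccc1NC(=O)c1ccc(CSc2ccc(Br)cc2)cc1` — 38.2%
compound 2, `Nc1ccccc1NC(=O)/C=C/c1ccc(CSc2ccc(F)cc2)cc1` — 10.4%
compound 3, `Nc1ccccc1NC(=O)c1ccc(CSc2ccc(C(F)(F)F)cn2)cc1` — 16.5%

All three were run in a functional assay on HeLa cells (Homo sapiens) for inhibition, read by CCK-8 assay, with a stated time of 72 h, tested at 8 uM; a lower number here means less inhibition of growth, a higher number more inhibition of growth at the concentration tested. Compound 1 stands highest of the three numbers; compound 3 comes nearest, its value lower by an amount beyond the usual scatter, and compound 2 lies furthest below, also beyond the scatter. Compound 4, `Cc1ccc(SCc2ccc(C(=O)Nc3ccccc3N)cc2)cc1`, has not yet been measured. It differs from compound 1 in one place: methyl in place of bromo on an aromatic carbon. No pair of measured compounds differs by this single change, so the size of the step cannot be read from the numbers shown. A small downward step, or none beyond the scatter, is expected: a number 7.2 percentage points lower from compound 1 to compound 4 (within the scatter). Compound 4 is expected to give 31%, with a range from 16% to 46%.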

Compound 4, percent growth inhibition at one concentration: 79.2%
Compound 4: middle estimate off by 48.2 percentage points, on the low side, outside the stated range (above it).
By their numbers in this assay, from the lowest: compounds 2 and 3 (each within the scatter of the next); then compound 1; then compound 4.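

In this assay, replacing 4-bromophenyl with 4-methylphenyl on the shared core gives a number 41 percentage points higher from compound 1 to compound 4 (beyond the scatter), so exchanging one heavy atom at this place on the aromatic ring can change growth inhibition strongly. The earlier compounds shown here could not show this, since no two of them differed in one place only. Nothing available accounts for the size of this step. The compounds shown leave open how hydrogen, chloro, ethyl, methoxy or an amine would read at this place. They also leave open whether methyl would bring a similar gain on another core.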